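The source may report more compounds than this note shows. Statements on the series, on what has been measured and on what is new or still open speak of the compounds shown alone.

Of the compounds shown here, three sharing one core have been measured in a functional assay on MDA-MB-231 cells (Homo sapiens) for antiproliferative activity, read by MTT assay, with a stated time of 48 h; on this read-out lower numbers stand for stronger inhibition and higher numbers for weaker inhibition. Compound 1 `COc1ccc(OC)c(/C=N/c2c(C#N)ncn2-c2ccc(F)cc2)c1` gives 12300 nM, compound 2 `COc1cc(/C=N/c2c(C#N)ncn2-c2ccc(F)cc2)ccc1O` gives 13600 nM, and compound 3 `N#Cc1ncn(-c2ccc(F)cc2)c1/N=C/c1ccc(O)cc1` gives 16300 nM. Compound 2 thus lies within the scatter of both other compounds, and the numbers do not set it apart from either.

Compound 4 `COc1ccc(/C=N/c2c(C#N)ncn2-c2ccc(F)cc2)cc1OC` has not yet been measured. It differs from compound 2 by methyl in place of hydrogen on an oxygen on an aromatic ring, with methyl in place of hydrogen on an oxygen on an aromatic ring, so that hydroxy becomes methoxy. Among the compounds with values here, no measured step makes this exact change. The nearest evidence is a 1.2-fold higher number from compound 2 to compound 3 (0.08 log units; within the scatter), where hydrogen replaces methoxy on an aromatic carbon, a small step that stays within the scatter. Compound 1 also bears on the question, since it carries methoxy groups and no hydroxy, and its 12300 nM lies within the scatter of the value of compound 2.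

On this evidence, no step beyond the scatter is expected in this assay, and no direction can be favoured. The expected change is small, and the estimated step is a 1.0-fold lower number from compound 2 to compound 4 (0.02 log units; within the scatter). For compound 4 the estimated value is 13000 nM, with an expected range from 7000 nM to 24000 nM.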

Compound 4, half-maximal inhibitory concentration: 4270 nM
Estimate against measurement, compound 4: 3.0-fold (0.48 log units) above, and the stated range ends above it.
By their numbers in this assay, from the lowest: compound 4; then compounds 1, 2 and 3 (each within the scatter of the next).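

In this assay, within the data shown here, turning the hydroxy of compound 2 into methoxy is the first single change to produce a step beyond the scatter: a 3.2-fold lower number from compound 2 to compound 4 (0.50 log units; beyond the scatter), a modest step. Among these compounds, the only earlier single change, where hydrogen replaces methoxy on an aromatic carbon, gave a 1.2-fold higher number from compound 2 to compound 3 (0.08 log units; within the scatter) and stayed within the scatter, so the earlier compounds gave no sign that one methyl on this oxygen on an aromatic ring could register at all in this read-out. Nothing available accounts for why this methyl shifts the number.

On these data alone, this rests on one pair of compounds, so it remains open whether the same methyl would give a step of similar size on the other oxygen-bearing compounds, or whether the step belongs to this arrangement of groups alone. As far as these compounds go, it also remains open whether a longer chain on the same oxygen, such as ethoxy or propoxy, would move the number further, and how an amine or a carboxylic acid in place of the hydroxy would read.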